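This account rests on a few compounds, and the source may have more. Where it says the series, first, only, none or still open, it means among the compounds named here.

Within the data shown here, in a functional assay on A549 cells (Homo sapiens) for antiproliferative activity, read by MTT assay (a lower number here means a stronger inhibitor, a higher number a weaker inhibitor), compound 1 `Cc1cccc(Nc2nccc(-c3ccc(Br)cc3)n2)c1` gives 63200 nM, the higher of the two numbers measured so far. Compound 2 `Clc1ccc(Nc2nccc(-c3ccc(Br)cc3)n2)cc1` gives 6110 nM. Among the measured compounds shown here, the one measured step is a 10-fold lower number from compound 1 to compound 2 (1.01 log units; beyond the scatter), which is large. It puts 4-chlorophenyl in place of 3-methylphenyl on a nitrogen on an aromatic ring, so it shows that this part of the molecule can move the number a long way, but it does not test methoxy. Compound 3 `COc1cccc(Nc2nccc(-c3ccc(Br)cc3)n2)c1` keeps the core of compound 1 and carries methoxy in place of methyl on an aromatic carbon. This is a narrower change than the measured step, so a smaller shift is expected, probably towards a lower number in this assay. The estimated change is a 2.1-fold lower number from compound 1 to compound 3 (0.32 log units; beyond the scatter). For compound 3 the expected value is 30000 nM, with an estimated range from 8000 nM to 90000 nM.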

Compound 3, half-maximal inhibitory concentration: 82700 nM
For compound 3 the middle estimate is 2.8-fold (0.44 log units) below the measured one, and the stated range covers the measured number.
By their numbers in this assay, from the lowest: compound 2; then compounds 1 and 3 (each within the scatter of the next).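

In this assay, replacing methyl with methoxy on this aromatic carbon, meta to a large group, gives a 1.3-fold higher number from compound 1 to compound 3 (0.12 log units; within the scatter), so compound 1 and compound 3 cannot be told apart. Adding one oxygen and one hydrogen-bond acceptor at this place therefore leaves the number within normal scatter, unlike the larger change that gave a 10-fold lower number from compound 1 to compound 2 (1.01 log units; beyond the scatter), and this position tolerates at least this one swap without a clear shift. No available evidence explains why the number holds steady here.

The chlorine in compound 2 differs from the methyl of compound 1 in both identity and ring position, so it remains open which of these accounts for the large step. Going by these compounds, it is also open whether an amine or a carboxylic acid on this same aromatic carbon would move the number beyond the scatter.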